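From a methylsulfanyl chain to a cyclobutyl ring

The compounds below may be only part of what the source reports. "The series", "measured", "known", "first", "only" and "open" are said of these compounds alone.

Of the compounds shown here, two sharing a common core have been measured in a physicochemical assay for solubility; a lower number here means a less soluble compound, a higher number a more soluble compound. Compound 1 `C#CCNC(=O)C[C@H](NC(=O)c1ccc(C#Cc2ccccc2)cc1)C(=O)NO` gives 8000 nM. Compound 2 `CSC[C@H](NC(=O)c1ccc(C#Cc2ccccc2)cc1)C(=O)NO` gives 2000 nM, the lowest of the two numbers; its nearest neighbour is compound 1, with a 4.0-fold lower number from compound 1 to compound 2 (0.60 log units; beyond the scatter). Compound 3 `O=C(NC1(C(=O)NO)CCC1)c1ccc(C#Cc2ccccc2)cc1` differs from compound 2 in one place: a group of 8 heavy atoms (5 carbon, 1 nitrogen, 2 oxygen; one four-membered non-aromatic ring of carbon only) in place of a group of 8 heavy atoms (4 carbon, 1 nitrogen, 2 oxygen, 1 sulfur; no ring), on an amide-type nitrogen. Within the data shown here, the only measured step, a 4.0-fold lower number from compound 1 to compound 2 (0.60 log units; beyond the scatter), bears on this move only loosely, as it exchanged one group on that chain while the chain itself stayed; it was of modest size, and nothing measured addresses a ring entering at the amide-type nitrogen. With so thin a basis, the expected step for compound 3 in this assay is none beyond the scatter, no change at the digits printed from compound 2 to compound 3 (within the scatter). Compound 3 is therefore estimated at 2000 nM, with a range from 700 nM to 6000 nM.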

Compound 3, solubility: 5000 nM
Beside the measured number, compound 3's estimate is 2.5-fold (0.40 log units) below it; the measured number falls inside the stated range.
By their numbers in this assay, from the lowest: compound 2; then compounds 3 and 1 (each within the scatter of the next).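

In this assay, the first ring-bearing group on the amide-type nitrogen gives a 2.5-fold higher number from compound 2 to compound 3 (0.40 log units; beyond the scatter), so this position has now shown a change beyond the scatter with a group of the same heavy-atom count. The exchange removes the sulfur and the defined stereocentre and brings in 1-(hydroxycarbamoyl)cyclobutyl, and compound 2 remains the lowest of the three compounds in this series. Nothing available explains the step.

The change alters several features at once, so the compounds shown do not separate the arrival of the four-membered ring from the departure of the sulfur or the stereocentre. Also open, from the compounds shown here alone, is how the read-out would respond to a cyclopentyl ring in place of the cyclobutyl ring, or to an amine carried on that ring.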